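Methyl on the Core: What to Expect in Breast Cancer Cells

The source may hold more compounds than are shown below. What is called first, only, known or untested is meant among the compounds shown, and "the series" means these compounds.

Compound 1 `O=c1c(CSC(=S)N2CCCC2)coc2ccccc12` in a functional assay on MCF7 cells (Homo sapiens) for antiproliferative activity, read by MTT assay, with a stated time of 72 h (on this read-out lower numbers stand for stronger inhibition and higher numbers for weaker inhibition), gives > 25000 nM, which is a limit of the assay and not a number.
Compound 2 `Cc1ccc2c(=O)c(CSC(=S)N3CCCC3)coc2c1` gives 41400 nM.
Compound 3 `O=c1c(CSC(=S)N2CCOCC2)coc2ccccc12` gives 4000 nM.

Because compound 1 sits at the limit of > 25000 nM in this assay, at which 1 of the 3 values shown sits, the step to compound 2, (methyl in place of hydrogen on an aromatic carbon), is a step that the limit leaves unreadable from compound 1 to compound 2. Compound 3 differs from compound 1 by morpholin-4-yl in place of pyrrolidin-1-yl on a thiocarbonyl carbon, and this gives an at least 6.2-fold lower number from compound 1 to compound 3 (0.79 log units; beyond the scatter). Compound 4 `Cc1ccc2c(=O)c(CSC(=S)N3CCOCC3)coc2c1` is not yet measured; it differs from compound 3 by methyl in place of hydrogen on an aromatic carbon, the same change as from compound 1 to compound 2. Among the compounds with values here, the one earlier example of this change yields no readable size, and compound 2 stays weak, so for compound 4 a step of a 1.5-fold higher number from compound 3 to compound 4 (0.18 log units; within the scatter) is expected, resting only on compound 3 and its value 4000 nM. Compound 4 is therefore estimated at 6000 nM, with a range from 2000 nM to 20000 nM.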

Compound 4, half-maximal inhibitory concentration: 20700 nM
For compound 4 the middle estimate is 3.5-fold (0.54 log units) below the measured one; the measured number lies above the stated range.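

In this assay, methyl in place of hydrogen on the compound carrying morpholin-4-yl gives a 5.2-fold higher number from compound 3 to compound 4 (0.71 log units; beyond the scatter). Morpholin-4-yl in place of pyrrolidin-1-yl on the methyl-bearing core gives a 2.0-fold lower number from compound 2 to compound 4 (0.30 log units; within the scatter), so this change does not carry over from one core to the other at the same size: the same change on two cores in this assay, an at least 6.2-fold lower number (0.79 log units; beyond the scatter) from compound 1 to compound 3 and a 2.0-fold lower number (0.30 log units; within the scatter) from compound 2 to compound 4, at least 3.1-fold (0.49 log units) apart, beyond the scatter of two such steps. Compound 1 stands at a limit of the assay and not a number (> 25000 nM), so the methyl step from it cannot be read, and these compounds do not show whether methyl has the same effect with pyrrolidin-1-yl as with morpholin-4-yl: the limit of > 25000 nM in this assay, at which 1 of the 4 values shown sits.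

Still open, going by these compounds, is how an ethyl or methoxy group would behave at the methyl's place. Also open, on these data alone, is whether piperidin-1-yl on the thiocarbonyl carbon would follow morpholin-4-yl or pyrrolidin-1-yl.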